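Shorter amide chain on the shared core: cytotoxicity notes

The source may hold more compounds than are shown below. What is called first, only, known or untested is meant among the compounds shown, and "the series" means these compounds.

Three analogues built on the core of compound 1 `CC(C)=CC(=O)Nc1ccn([C@H]2C[C@@H](O)[C@H](O)[C@@H](C)O2)c(=O)n1` have been run in a functional assay on HCT-116 cells (Homo sapiens) for cytotoxicity, read by sulforhodamine B assay, with a stated time of 24 h; a higher number here means a weaker inhibitor, a lower number a stronger inhibitor. Compound 1 returns only a limit, > 20000 nM. Compound 2 `C[C@H]1O[C@@H](n2ccc(NC(=O)CC(C)(C)O)nc2=O)CC[C@@H]1O` likewise returns only a limit, > 20000 nM. Compound 3 `CC(=O)C(C)Nc1ccc(C(=O)Nc2ccn([C@H]3CC[C@H](O)[C@@H](C)O3)c(=O)n2)cc1` also returns a limit, > 20000 nM. Compound 2 therefore stands where the other two stand, at the limit of > 20000 nM in this assay, at which 3 of the 3 values shown sit, with no number to rank it. Among the measured compounds shown here, no step between measured compounds is available. Compound 4 `CCC(=O)Nc1ccn([C@H]2CC[C@H](O)[C@@H](C)O2)c(=O)n1` differs from compound 2 by methyl in place of 1-hydroxy-1-methylethyl on a saturated chain carbon bound to a carbonyl carbon. With every value shown sitting at the limit, no direction can be read, and the step from compound 2 to compound 4 is expected to be none beyond the scatter, a step that the limit leaves unreadable from compound 2 to compound 4. Compound 4 is estimated at 30000 nM, within 10000 nM to 100000 nM, most likely reported again as a limit.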

Compound 4, half-maximal inhibitory concentration: > 20000 nM
Compound 4 was reported as a limit (the forecaster's own chance of this, stated with the estimate: 85%); the middle value does not contradict the limit.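

No step can be read from compound 2 to compound 4, since both values are limits: the limit of > 20000 nM in this assay, at which 4 of the 4 values shown sit. The compounds shown leave open whether any amide chain on the shared core gives a readable value.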